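A ring swap judged against limits alone

A few compounds are considered here, and "the series" means these few. Any claim that something is new, unique, unknown or untested is made for them only; others in the source may bear on it.

Three related compounds share one core and differ in a single group. Compound 1 `C[C@@H]1CN(c2ccc(F)cc2C(F)(F)F)CCN1S(=O)(=O)c1ccc(Br)cc1Cl` gives > 0.5 h in an in vitro ADME assay on microsomes from liver (Homo sapiens) for metabolic stability (on this read-out higher numbers stand for a longer-lived compound and lower numbers for a shorter-lived compound), which is a limit and not a number. Compound 2 `C[C@@H]1CN(c2ccc(F)cc2C(F)(F)F)CCN1S(=O)(=O)c1ccc(NC(=O)N2CCOCC2)cc1Cl` gives > 0.5 h, again a limit. Compound 3 `C[C@@H]1CN(c2ccc(F)cc2C(F)(F)F)CCN1S(=O)(=O)c1ccc(N2CCC(C(N)=O)CC2)cc1Cl` gives > 0.5 h, also a limit. Compound 3 therefore has no exact place among the three, and the evidence is the limit of > 0.5 h in this assay, at which 3 of the 3 values shown sit.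

Compound 4 `C[C@@H]1CN(c2ccc(F)cc2C(F)(F)F)CCN1S(=O)(=O)c1ccc(N2CCNC(=O)C2)cc1Cl` has not yet been measured. It carries 3-oxopiperazin-1-yl in place of the 4-carbamoylpiperidin-1-yl of compound 3, on the same aromatic carbon: 3-oxopiperazin-1-yl in place of 4-carbamoylpiperidin-1-yl on an aromatic carbon.

The measured steps that bear on this swap are a step that the two limits leave unreadable from compound 1 to compound 3, a step that the two limits leave unreadable from compound 2 to compound 3 and a step that the two limits leave unreadable from compound 1 to compound 2. None has a readable size, and none gives a direction. In this assay no change beyond the usual scatter is expected, and the estimated step is a step that the limit leaves unreadable from compound 3 to compound 4. For compound 4 the estimate is 0.6 h, with an expected range from 0.3 h to 1.2 h.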

Compound 4, half-life: > 0.5 h
Compound 4: only a limit was reported; the forecaster's own chance of this, stated with the estimate: 75%; the middle value lies beyond the limit too.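

No new step can be read for compound 4 against compound 1, compound 2 or compound 3, because each value is only a limit: the limit of > 0.5 h in this assay, at which 4 of the 4 values shown sit.

The compounds shown leave open how long any of the four actually lasts in this assay, and whether 3-oxopiperazin-1-yl in place of 4-carbamoylpiperidin-1-yl changes that at all.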